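Swapping a Saturated Bromoamide Chain for an Unsaturated One

A few compounds are considered here, and "the series" means these few. Any claim that something is new, unique, unknown or untested is made for them only; others in the source may bear on it.

Three compounds share one core, a trimethoxyphenyl ring carried on an amide nitrogen, and were tested in a functional assay on HCT-116 cells (Homo sapiens) for inhibition, read by MTT assay, with a stated time of 48 h; on this read-out higher numbers stand for weaker inhibition and lower numbers for stronger inhibition. Compound 1 `COc1ccc(CN(C(=O)C(C)Br)c2cc(OC)c(OC)c(OC)c2)cc1O` gives the lowest number of the three, with 140 nM in this assay. Its nearest neighbour on that scale, compound 2 `C/C=C/C(=O)N(Cc1ccc(OC)c(N)c1)c1cc(OC)c(OC)c(OC)c1`, gives 300 nM, a gap that lies beyond the scatter of repeated measurements. Compound 3 `COc1cc(NCc2cccc(O)c2)cc(OC)c1OC`, which lacks the amide altogether, gives 67700 nM in this assay, far weaker than either.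

Compound 4 `COc1ccc(CN(C(=O)/C=C/CBr)c2cc(OC)c(OC)c(OC)c2)cc1O` is not yet measured. It differs from compound 1 in a single place: 3-bromoprop-1-en-1-yl in place of 1-bromoethyl on a carbonyl carbon. The rest of the molecule, including the hydroxy and methoxy groups on the benzyl ring, is unchanged.

Among the compounds with values here, no pair of measured compounds isolates this particular change, so the expectation rests on the neighbours. Compound 2 shows that an amide of this kind can keep a low number in this assay, so a step from compound 1 that stays close to its own value is expected. The estimated step is a 1.2-fold lower number from compound 1 to compound 4 (0.07 log units; within the scatter), which is within the usual scatter, neither clearly stronger nor clearly weaker. Compound 4 is therefore estimated at 120 nM in this assay, with a range from 40 nM to 400 nM.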

Compound 4, half-maximal inhibitory concentration: 59 nM
Beside the measured number, compound 4's estimate is 2.0-fold (0.31 log units) above it, within the range that was stated.
By their numbers in this assay, from the lowest: compound 4; then compound 1; then compound 2; then compound 3.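

Within the data shown here, the swap of 1-bromoethyl for 3-bromoprop-1-en-1-yl on a carbonyl carbon gives the first step in this set that changes one place only, and in this assay it reads as a 2.4-fold lower number from compound 1 to compound 4 (0.38 log units; beyond the scatter). The step is modest, but it shows that this place accepts a longer chain carrying a double bond, and that inhibition in this assay gets stronger rather than merely holding steady. Nothing available here explains the size or the direction of this step.

Going by these compounds, this one step changes the chain length, the double bond and the place of the bromine together, so their separate contributions remain unknown, and a saturated 3-bromopropyl chain on the same carbonyl carbon would help to pull them apart. On these data alone, whether bromine itself matters in this chain also stays open, and a chlorine atom in its place, with the rest of compound 4 unchanged, would address that question.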